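Expected Cytotoxicity After Replacing the Sulfonyl Group in Compound 1

A few compounds are considered here, and "the series" means these few. Any claim that something is new, unique, unknown or untested is made for them only; others in the source may bear on it.

Measured compounds:
Compound 1 `C[C@@H](Cn1ccc(-c2ccc(C#N)c(Cl)c2)n1)NS(=O)(=O)c1cccnc1` – > 30000 nM
Compound 2 `C[C@@H](Cn1ccc(-c2cc(F)c(C#N)c(Cl)c2)n1)NC(=O)Nc1cc(C(C)(C)C)[nH]n1` – > 30000 nM

Both measured compounds were tested in an ADME assay on PC-3 cells (Homo sapiens) for cytotoxicity, read by CCK-8 assay, with a stated time of 6 days; on this read-out lower numbers stand for stronger inhibition and higher numbers for weaker inhibition. Compound 1 gives > 30000 nM, which is a limit of the assay and not a number. Compound 2 gives > 30000 nM, which is likewise a limit. Going by the values given here, compound 1 therefore stands at the limit, and the only other value shown sits at the same place (the limit of > 30000 nM in this assay, at which 2 of the 2 values shown sit). Among the compounds with values here, no step between two measured compounds that differ in one place can be drawn from this, so the numbers say only that neither compound showed measurable toxicity within the range tested.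

Compound 3 `Cc1ccnc(N[C@@H](C)Cn2ccc(-c3ccc(C#N)c(Cl)c3)n2)n1` is the compound to be measured. It differs from compound 1 by 4-methylpyrimidin-2-yl in place of (pyridin-3-yl)sulfonyl on an amine nitrogen. Within the data shown here, there is no measured step to lean on, so the expectation rests on where the measured compounds sit. Because both shown values lie at the limit (the limit of > 30000 nM in this assay, at which 2 of the 2 values shown sit), compound 3 is expected to sit there too, with an expected step of a number no higher from compound 1 to compound 3 (the limit leaves the size open), none beyond the scatter. The estimate for compound 3 is 30000 nM, with a range from 10000 nM to 100000 nM.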

Compound 3, half-maximal inhibitory concentration: > 30000 nM
Compound 3: a limit, no number; the forecaster's own chance of this, stated with the estimate: 75%; the middle value lies on the limit itself.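

No step from compound 1 to compound 3 can be read, because both results are limits of the assay and not numbers: the limit of > 30000 nM in this assay, at which 3 of the 3 values shown sit.

The compounds shown leave open how far past that limit each one lies, and so whether the change from compound 1 to compound 3 alters cytotoxicity at all.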